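The source may report more compounds than this note shows. Statements on the series, on what has been measured and on what is new or still open speak of the compounds shown alone.

Three compounds of the series share a core carrying two carboxylic acid thioether arms and differ only in the chain on the aromatic ring. In an assay on membranes from lung (Cavia porcellus) for binding affinity to cysteinyl leukotriene receptor (Homo sapiens) (on this read-out lower numbers stand for stronger inhibition and higher numbers for weaker inhibition), compound 1 `CCCCCCCCCCCCCCc1ccccc1C(SCCC(=O)O)SCCC(=O)O` gives 1250 nM, compound 2 `CCCCCCCCCCc1ccccc1C(SCCC(=O)O)SCCC(=O)O` gives 1180 nM and compound 3 `CCCCC/C=C/C/C=C/COc1ccccc1C(SCCC(=O)O)SCCC(=O)O` gives 1000 nM. The numbers of compounds 3, 2 and 1 all lie within the scatter of one another, so compound 3 is not set apart from the other two. Among the compounds with values here, the one step measured so far, a 1.1-fold lower number from compound 1 to compound 2 (0.03 log units; within the scatter), concerns only the length of a saturated chain.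

Compound 4 `O=C(O)CCSC(SCCC(=O)O)c1ccccc1OCCCCCCCCCO` differs from compound 3 by 8-hydroxyoctyl in place of deca-1,4-dien-1-yl on a saturated chain carbon bound to an oxygen on an aromatic ring. Within the data shown here, no measured step covers the entry of a hydroxyl or the loss of the double bonds; the only guide is that the chain shortening from compound 1 to compound 2 left this assay unchanged. For compound 4 a number close to that of compound 3 is therefore expected, with a 1.4-fold higher number from compound 3 to compound 4 (0.15 log units; within the scatter) as the estimated step, and the estimate for compound 4 is 1400 nM within the range 400 nM to 5000 nM.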

Compound 4, inhibition constant: > 20000 nM
Compound 4: no number, only a limit; the forecaster's own chance of this, stated with the estimate: 10%; middle value at least 14-fold (1.15 log units) away from the limit.
By their numbers in this assay, from the lowest: compounds 3, 2 and 1 (each within the scatter of the next). At a limit, above all of these: compound 4.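

In this assay compound 4 gives > 20000 nM, which is a limit of the assay and not a number. Within the data shown here, on a saturated chain carbon bound to an oxygen on an aromatic ring, 8-hydroxyoctyl in place of deca-1,4-dien-1-yl brings an at least 20-fold higher number from compound 3 to compound 4 (1.30 log units; beyond the scatter), the first step beyond the scatter. Among these compounds, the only earlier step, a 1.1-fold lower number from compound 1 to compound 2 (0.03 log units; within the scatter), gave no sign of this, so the chain on the aromatic ring is not indifferent to every change.

This single step joins the entry of the hydroxyl with the loss of the double bonds, and the compounds shown do not separate the two. Open, from the compounds shown here alone, is how a plain octyl chain at this place would read out, or a carboxylic acid or an amine in place of the hydroxyl.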